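Adding to the aromatic ring of compound 2

The source may hold more compounds than are shown below. What is called first, only, known or untested is meant among the compounds shown, and "the series" means these compounds.

Compound 1 `N#Cc1ccc(Cn2cncc2CN2CCN(c3cccc(Cl)c3)C(=O)C2=O)cc1` in a physicochemical assay for lipophilicity; a higher number here means a more lipophilic compound, a lower number a more polar compound: 1.24
Compound 2 `N#Cc1ccc(Cn2cncc2CN2CCN(c3ccccc3)C(=O)C2=O)cc1` in this assay: 0.46

Among the measured compounds shown here, of these two compounds, compound 2 holds the lower number in this assay, and the only neighbour is compound 1 at 1.24. Compound 3 `Cc1cccc(N2CCN(Cc3cncn3Cc3ccc(C#N)cc3)C(=O)C2=O)c1C` has not yet been measured. It differs from compound 2 by one change, 2,3-dimethylphenyl in place of phenyl on an amide-type nitrogen in a ring. For the measured compounds named here, one measured step bears on this, with hydrogen in place of chloro on an aromatic carbon: a number 0.78 log units lower from compound 1 to compound 2 (beyond the scatter). Read backwards, that modest step shows a higher number with the larger group. Going by the values given here, it is only a loose guide, since no compound with the 2,3-dimethylphenyl group has been measured. A modest rise of similar size is therefore expected, an estimated a number 0.84 log units higher from compound 2 to compound 3 (beyond the scatter). Compound 3 is expected at 1.3, within an estimated range of 0.9 to 1.7.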

Compound 3, partition coefficient: 1.11
Beside the measured number, compound 3's estimate is 0.19 log units above it; the range from low to high includes it.
By their numbers in this assay, from the lowest: compound 2; then compounds 3 and 1 (each within the scatter of the next).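

The position on the amide-type nitrogen now has a second substituted aromatic ring: in this assay, 2,3-dimethylphenyl in place of phenyl gives a number 0.65 log units higher from compound 2 to compound 3 (beyond the scatter), so a step of this modest kind is no longer seen with chloro alone. Set against 3-chlorophenyl, the same group gives a number 0.13 log units lower from compound 1 to compound 3 (within the scatter), so the two substituted rings cannot be told apart in this read-out, even though they share no substituent. The data offer no measured explanation for either step.

Going by these compounds, compound 3 carries its two methyl groups together, and what each contributes alone stays open. Also open, on these data alone, is how this assay would respond at this position to an aromatic ring bearing an amine or a carboxylic acid.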